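The source may hold more compounds than are shown below. What is called first, only, known or untested is meant among the compounds shown, and "the series" means these compounds.

Measured so far:

Compound 1, `CCCCNC(=O)OCC(O)Cn1cc(CN(C)CCC(C)C)nn1`, in an assay on nucleic acid for inhibition of Nucleic Acid, read by fluorescence, tested at 100 uM (a higher number here means more inhibition at the concentration tested (going by the name of the read-out), a lower number less inhibition), gives 24%.
Compound 2, `CC(C)CCN(C)Cc1cn(CC(O)COC(=O)NCc2ccccc2)nn1`, in this assay gives 26%.
Compound 3, `CCCCNC(=O)OCC(O)Cn1cc(CN(C)CC2CCCCC2)nn1`, in this assay gives 12%.

Compound 4, `CN(Cc1cn(CC(O)COC(=O)NCc2ccccc2)nn1)CC1CCCCC1`, has not yet been measured. It is built from compound 3 by one change, (phenyl in place of propyl on a saturated chain carbon bound to an amide-type nitrogen). The same change has already been made once, from compound 1 to compound 2, (phenyl in place of propyl on a saturated chain carbon bound to an amide-type nitrogen), and there it gave a number 2 percentage points higher from compound 1 to compound 2 (within the scatter). The place of the change is the same in both pairs, so this counts as the same change, made on a different core. The two cores differ in one way, (cyclohexyl in place of isobutyl on a saturated chain carbon bound to an amine nitrogen), which gave a number 12 percentage points lower from compound 1 to compound 3 (beyond the scatter), so compound 3 starts from a lower value than compound 1 did.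

Because a number 2 percentage points higher from compound 1 to compound 2 (within the scatter) was within the scatter, the expectation for compound 4 is a step of about a number 2 percentage points higher from compound 3 to compound 4 (within the scatter), with no real gain or loss from the change. On that basis compound 4 is estimated to give 14%, most likely between 3% and 26%, in this assay.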

Compound 4, a percentage reported as inhibition, at one concentration (the size of the read-out at that concentration, not a potency): 32%
Compound 4: middle estimate off by 18 percentage points, on the low side; the whole stated range lies below it.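

In this assay, phenyl in place of propyl gave a number 20 percentage points higher from compound 3 to compound 4 (beyond the scatter), so the change did not carry over at the same size from the core with isobutyl to the core with cyclohexyl: the same change on two cores in this assay, a number 2 percentage points higher (within the scatter) from compound 1 to compound 2 and a number 20 percentage points higher (beyond the scatter) from compound 3 to compound 4, 18 percentage points apart, beyond the scatter of two such steps. The same four compounds can be read through the other change, where cyclohexyl in place of isobutyl, now with phenyl already present, gave a number 6 percentage points higher from compound 2 to compound 4 (within the scatter), which also departs from the earlier step: the same change on two cores in this assay, a number 12 percentage points lower (beyond the scatter) from compound 1 to compound 3 and a number 6 percentage points higher (within the scatter) from compound 2 to compound 4, 18 percentage points apart, beyond the scatter of two such steps. Together these show that, in these four compounds, the effect of each change depends on the group at the other place, but they are a single comparison read in two ways, at one concentration, and they give no reason for the dependence and no rule for other cores.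

The compounds shown leave open whether the rise needs the phenyl ring itself, or whether a cyclohexyl ring or a longer chain at the same place would also give it. As far as these compounds go, it is also open whether the dependence would hold with a longer chain in place of isobutyl and cyclohexyl on the amine side.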